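Chloro on the Shared Core: From Compound 2 to Compound 3

The compounds below may be only part of what the source reports. "The series", "measured", "known", "first", "only" and "open" are said of these compounds alone.

Measured so far:
compound 1 `CCN1CCC(NC(=O)c2cccc3[nH]cnc23)CC1`: 1000 nM
compound 2 `CS(=O)(=O)NCCN1CCC(COC(=O)c2cccc3[nH]cnc23)CC1`: 26.3 nM

Of the compounds shown here, two have been measured in an assay on membranes from striatum with 5-hydroxytryptamine receptor 4 (Rattus norvegicus) as the target; on this read-out higher numbers stand for weaker inhibition and lower numbers for stronger inhibition. Compound 1 gives 1000 nM, and compound 2 gives 26.3 nM, the lower of the two numbers, with a gap to compound 1 that lies beyond the scatter. Compound 3 `CS(=O)(=O)NCCN1CCC(COC(=O)c2cc(Cl)cc3[nH]cnc23)CC1` differs from compound 2 in one place: chloro in place of hydrogen on an aromatic carbon, on a carbon meta to a fused ring and para to a fused ring. Going by the values given here, no measured pair shows this change, so its effect here is unknown. Compound 3 is therefore expected to stay close to compound 2, at an estimated 20 nM, between 6 nM and 70 nM. The expected step is a 1.3-fold lower number from compound 2 to compound 3 (0.12 log units; within the scatter), within the scatter.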

Compound 3, inhibition constant: 2.29 nM
Beside the measured number, compound 3's estimate is 8.7-fold (0.94 log units) above it; measured number outside the range, below it.
By their numbers in this assay, from the lowest: compound 3; then compound 2; then compound 1.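

This position on the shared core is far from silent: in this assay, chloro in place of hydrogen on this aromatic carbon, a change of one heavy atom, gives an 11-fold lower number from compound 2 to compound 3 (1.06 log units; beyond the scatter). Going by these compounds alone, the earlier compounds held no step at this carbon, so this pair is the first to show that the read-out responds to a change here. Nothing shown explains why the number moves. From the compounds shown here alone, whether fluoro, bromo or methyl on the same carbon would give a similar step remains open. So does whether chloro would have a step of this size in compound 1.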